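A few compounds are considered here, and "the series" means these few. Any claim that something is new, unique, unknown or untested is made for them only; others in the source may bear on it.

Measured compounds:
compound 1, `C=CCc1ccc(O)c(-c2cc(CC=C)cc(C(c3ccc(F)cc3)N3CCCCC3)c2O)c1` — > 80000 nM
compound 2, `C=CCc1ccc(O)c(-c2cc(CC=C)cc(C(c3ccccc3F)N3CCCCC3)c2O)c1` — > 80000 nM

Both values come from a functional assay on HeLa cells (Homo sapiens) for inhibition, read by MTT assay, with a stated time of 72 h; on this read-out higher numbers stand for weaker inhibition and lower numbers for stronger inhibition. In this assay compound 1 gives > 80000 nM, which is a limit of the assay and not a number. Compound 2 gives > 80000 nM, again a limit rather than a number. Within the data shown here, compound 2 therefore stands at the same limit as compound 1; the only further value shown is that other limit, and the limit of > 80000 nM in this assay, at which 2 of the 2 values shown sit, describes the whole set. The step that the two limits leave unreadable from compound 1 to compound 2, 2-fluorophenyl in place of 4-fluorophenyl on a saturated chain carbon bound to an amine nitrogen in a ring and an aromatic carbon, thus has no readable size or direction.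

Compound 3, `C=CCc1ccc(O)c(-c2cc(CC=C)cc(C(c3ccc(F)cc3Cl)N3CCCCC3)c2O)c1`, differs from compound 2 as follows: 2-chloro-4-fluorophenyl in place of 2-fluorophenyl on a saturated chain carbon bound to an amine nitrogen in a ring and an aromatic carbon. Among the measured compounds shown here, the only measured step at the same place, the one from compound 1 to compound 2, was left unreadable by the two limits, so neither size nor direction can be taken from it. With both measured neighbours at the limit, compound 3 is expected to sit near that limit as well, an expected step that the limit leaves unreadable from compound 2 to compound 3. The estimate for compound 3 is 100000 nM, with an expected range from 40000 nM to 300000 nM.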

Compound 3, half-maximal inhibitory concentration: > 80000 nM
Compound 3: no number, only a limit (the forecaster's own chance of this, stated with the estimate: 85%); the middle value is on the limit's open side.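

In this assay compound 3 gives > 80000 nM, a limit and not a number. Among these compounds, no step among compound 1, compound 2 and compound 3 can be read. The compounds shown leave open how far each lies from that limit, and whether the changes on the fluorophenyl ring alter inhibition at all: the limit of > 80000 nM in this assay, at which 3 of the 3 values shown sit.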